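Furan-2-yl for Phenyl on a Hydrazide Nucleoside

The compounds below may be only part of what the source reports. "The series", "measured", "known", "first", "only" and "open" are said of these compounds alone.

Compound 1 `CCNC(=O)[C@H]1O[C@@H](n2cnc3c(NNC(=O)c4ccccc4)ncnc32)[C@H](O)[C@@H]1O`: > 5000 nM
Compound 2 `CCNC(=O)[C@H]1O[C@@H](n2cnc3c(NNC(=O)c4ccccc4)nc(Cl)nc32)[C@H](O)[C@@H]1O`: > 5000 nM

Of the compounds shown here, two have been measured in a functional assay on CHO cells for activation of adenosine receptor A2b (Homo sapiens), read by cAMP accumulation; on this read-out lower numbers stand for an effect already at smaller amounts and higher numbers for an effect only at larger amounts of compound. For compound 1 the value > 5000 nM is a limit of the assay, not a number. For compound 2 the value > 5000 nM is likewise only a limit. The step that the two limits leave unreadable from compound 1 to compound 2 therefore cannot be read, because both values sit at the limit of > 5000 nM in this assay, at which 2 of the 2 values shown sit. Compound 2 thus stands at the limit itself, with no measured number of its own.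

Compound 3 `CCNC(=O)[C@H]1O[C@@H](n2cnc3c(NNC(=O)c4ccco4)nc(Cl)nc32)[C@H](O)[C@@H]1O` differs from compound 2 by furan-2-yl in place of phenyl on a carbonyl carbon. Going by the values given here, no measured step touches this change, and the only measured step, the one from compound 1 to compound 2, gives no readable size. With both known compounds at the limit, compound 3 is expected to stay near it as well: the estimate for compound 3 in this assay is 8000 nM, within a range from 2500 nM to 30000 nM, which corresponds to an expected step that the limit leaves unreadable from compound 2 to compound 3.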

Compound 3, half-maximal effective concentration: 210 nM
Estimate against measurement, compound 3: 38-fold (1.58 log units) above; measured number outside the range, below it.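

In this assay, furan-2-yl in place of phenyl on the carbonyl carbon gives an at least 23-fold lower number from compound 2 to compound 3 (1.37 log units; beyond the scatter), so this place on the molecule is the first shown where a single change moves the read-out clearly away from the limit. The value of compound 2, > 5000 nM, is a limit of the assay, not a number. The earlier chloro in place of hydrogen could show nothing of this kind, and that step cannot be read because both of its compounds sit at the same limit: the limit of > 5000 nM in this assay, at which 2 of the 3 values shown sit.

The compounds shown do not tell whether the ring oxygen or the smaller five-membered ring goes with this change, or how thiophen-2-yl, with sulfur in the ring, would read at this carbonyl carbon. As far as these compounds go, it also stays open whether furan-2-yl would give a similar read-out with hydrogen in place of the chloro.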